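This account rests on a few compounds, and the source may have more. Where it says the series, first, only, none or still open, it means among the compounds named here.

Measured in an assay on HEK cells for antagonist activity at transient receptor potential cation channel subfamily V member 1 (Homo sapiens), read by FLIPR; a higher number here means a weaker inhibitor, a lower number a stronger inhibitor:

compound 1 `O=C(NCc1ccc(C(F)(F)F)nc1N1CCCCC1)Nc1cccc2[nH]c(=O)ccc12`: 0.75 nM
compound 2 `CCCCCCOc1nc(C(F)(F)F)ccc1CNC(=O)Nc1cccc2[nH]c(=O)ccc12`: 3.19 nM
compound 3 `CC(C)COc1nc(C(F)(F)F)ccc1CNC(=O)Nc1cccc2[nH]c(=O)ccc12`: 2.6 nM

Compound 3 stands second highest of the three numbers. Its nearest neighbour is compound 2, with a 1.2-fold lower number from compound 2 to compound 3 (0.09 log units; within the scatter); its furthest is compound 1, with a 3.5-fold higher number from compound 1 to compound 3 (0.54 log units; beyond the scatter). The two alkoxy compounds thus sit close to each other, while both lie apart from compound 1, as a 4.3-fold higher number from compound 1 to compound 2 (0.63 log units; beyond the scatter) also shows.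

Compound 4 `O=C(NCc1ccc(C(F)(F)F)nc1OCC1CCCC1)Nc1cccc2[nH]c(=O)ccc12` differs from compound 3 by cyclopentyl in place of isopropyl on a saturated chain carbon bound to an oxygen on an aromatic ring. The step that bears most directly on this change is the one between the two alkoxy compounds, a 1.2-fold lower number from compound 2 to compound 3 (0.09 log units; within the scatter), which stayed within the scatter although the chain changed in length and branching. The steps from compound 1 concern the exchange of piperidin-1-yl for an alkoxy group and do not speak to the shape of the alkoxy chain. On that basis, no step beyond the scatter is expected for compound 4 in this assay, which amounts to an expected 1.0-fold lower number from compound 3 to compound 4 (0.02 log units; within the scatter). Compound 4 is therefore estimated at 2.5 nM, with a range from 1.2 nM to 6 nM.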

Compound 4, half-maximal inhibitory concentration: 2.18 nM
For compound 4 the middle estimate is 1.1-fold (0.06 log units) above the measured one; low and high end bracket the measured number.
By their numbers in this assay, from the lowest: compound 1; then compounds 4, 3 and 2 (each within the scatter of the next).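

In this assay, a ring can enter the alkoxy chain without a step beyond the scatter: cyclopentyl gives the same reading in place of isopropyl (a 1.2-fold lower number from compound 3 to compound 4 (0.08 log units; within the scatter)) and in place of pentyl (a 1.5-fold lower number from compound 2 to compound 4 (0.17 log units; within the scatter)), so compounds 2, 3 and 4 cannot be told apart. The gap to the piperidin-1-yl group also holds with this ring in the chain (a 2.9-fold higher number from compound 1 to compound 4 (0.46 log units; beyond the scatter)), making cyclopentylmethoxy the third alkoxy group to stand apart from compound 1. Nothing given here explains the level alkoxy series or that gap.

From the compounds shown here alone, whether a chain ending in a hydroxyl or dimethylamino group would read the same as these carbon-only chains remains open. Going by these compounds, it is also open whether another cyclic amine, such as morpholin-4-yl, would match the lower number of compound 1.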